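The source may hold more compounds than are shown below. What is called first, only, known or untested is meant among the compounds shown, and "the series" means these compounds.

Compound 3 `CC1=C(C(=O)Nc2ccc([N+](=O)[O-])cc2)C(c2cccc([N+](=O)[O-])c2)N=C(SCc2ccccc2)N1` gives 14.9% in a functional assay on the whole organism (artery, strain albino) with Rattus norvegicus as the target, with a stated time of 900 min, at a dose of 10 mg/kg by the oral route; on this read-out higher numbers stand for more inhibition at the one dose given (going by the name of the read-out) and lower numbers for less inhibition. Among the three measured compounds it stands second highest, though all three sit within the scatter of one another: compound 1 `CC1=C(C(=O)Nc2ccc(F)cc2)C(c2ccc([N+](=O)[O-])cc2)N=C(SCc2ccccc2Cl)N1` gives 11.3% and compound 2 `CC1=C(C(=O)Nc2ccc([N+](=O)[O-])cc2)C(c2ccc(Br)cc2)N=C(SCc2ccccc2)N1` gives 19.5% in this assay. Among the measured compounds shown here, the only single-point step measured, a number 4.6 percentage points lower from compound 2 to compound 3 (within the scatter), concerned the group on the saturated ring carbon and did not reach beyond the scatter.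

Compound 4 `CC1=C(C(=O)Nc2ccc([N+](=O)[O-])cc2)C(c2cccc([N+](=O)[O-])c2)N=C(SCc2ccc(Cl)cc2)N1` differs from compound 3 by chloro in place of hydrogen on an aromatic carbon. For the measured compounds named here, no measured step tests this kind of change; compound 1 carries a chloro on its benzyl group too, but differs from compound 3 in other places as well. With nothing to point either way, the expected step is a number 0.1 percentage points higher from compound 3 to compound 4 (within the scatter), nothing beyond the scatter. Compound 4 is therefore estimated at 15%, between 5% and 26%.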

Compound 4, a percentage reported as inhibition, in the whole organism at one dose (the size of the read-out at that dose, not a potency): 12.3%
Beside the measured number, compound 4's estimate is 2.7 percentage points above it; measured number inside the range.
By their numbers in this assay, from the lowest: compounds 1, 4, 3 and 2 (each within the scatter of the next).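

Going from benzylsulfanyl to (4-chlorobenzyl)sulfanyl gives a number 2.6 percentage points lower from compound 3 to compound 4 (within the scatter) in this assay and so adds a first measured change on this benzyl group. At this position, chloro in place of hydrogen gives no difference that can be told from the scatter. No supporting measurement bears on this result.

From the compounds shown here alone, it remains open whether an amine or a carboxylic acid at this aromatic carbon would give a number beyond the scatter. Going by these compounds, it also remains open whether chloro would give the same result with a different group on the saturated ring carbon.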